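Chain Extension on the Ester of a Quinazoline Cytotoxin

The source may report more compounds than this note shows. Statements on the series, on what has been measured and on what is new or still open speak of the compounds shown alone.

Compound 3 `CCCCCCCCCCOC(=O)CCC(=O)N1CCN(CCCOc2cc3c(Nc4ccc(F)c(Cl)c4)ncnc3cc2OC)CC1` gives 2% in a functional assay on A549 cells (Homo sapiens) for cytotoxicity, read by MTT assay, with a stated time of 24 h, tested at 80 uM (a lower number here means a stronger effect, a higher number a weaker effect of the compound at the concentration tested), the lowest of the three numbers. Compound 1 `CCOC(=O)CCC(=O)N1CCN(CCCOc2cc3c(Nc4ccc(F)c(Cl)c4)ncnc3cc2OC)CC1` gives 35.6% and compound 2 `CCCCCCOC(=O)CCC(=O)N1CCN(CCCOc2cc3c(Nc4ccc(F)c(Cl)c4)ncnc3cc2OC)CC1` gives 42.9% in this assay. The steps were a number 7.3 percentage points higher from compound 1 to compound 2 (within the scatter), a number 33.6 percentage points lower from compound 1 to compound 3 (beyond the scatter) and a number 40.9 percentage points lower from compound 2 to compound 3 (beyond the scatter). Compound 4 `CCCCCCCCCCCCCCOC(=O)CCC(=O)N1CCN(CCCOc2cc3c(Nc4ccc(F)c(Cl)c4)ncnc3cc2OC)CC1` differs from compound 3 by butyl in place of hydrogen on a saturated chain carbon, ten or more bonds along the chain from an oxygen next to a carbonyl group. The two large lowerings into compound 3 bear on this step, though the step from compound 1 to compound 2 did not move beyond the scatter. Since compound 3 already sits near the bottom of the scale, the step to compound 4 is expected to be a number 2 percentage points higher from compound 3 to compound 4 (within the scatter), not beyond the scatter. Compound 4 is therefore estimated at 4%, within 0% to 18%.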

Compound 4, a percentage reported as activity, at one concentration (the size of the read-out at that concentration, not a potency): 77.2%
Compound 4: the middle estimate sits 73.2 percentage points below what was measured, and the stated range ends below it.
By their numbers in this assay, from the lowest: compound 3; then compounds 1 and 2 (each within the scatter of the next); then compound 4.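

Chain length at this position does not shift the number in this assay steadily: it falls into compound 3 and then turns back, with a number 75.2 percentage points higher from compound 3 to compound 4 (beyond the scatter) and a number 34.3 percentage points higher from compound 2 to compound 4 (beyond the scatter) and also a number 41.6 percentage points higher from compound 1 to compound 4 (beyond the scatter) so that compound 4 shows the weakest effect of the four at this concentration. The same butyl change differs greatly in size with the chain it extends: the same change on two cores in this assay, a number 7.3 percentage points higher (within the scatter) from compound 1 to compound 2 and a number 75.2 percentage points higher (beyond the scatter) from compound 3 to compound 4, 67.9 percentage points apart, beyond the scatter of two such steps. Octyl also moves the number in opposite directions: the same change on two cores in this assay, a number 33.6 percentage points lower (beyond the scatter) from compound 1 to compound 3 and a number 34.3 percentage points higher (beyond the scatter) from compound 2 to compound 4, 67.9 percentage points apart, beyond the scatter of two such steps.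

On these data alone, whether the turn between compound 3 and compound 4 is sharp or gradual stays open. As far as these compounds go, how a longer chain or a carboxylic acid in place of the ester would read also stays open.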